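The compounds below may be only part of what the source reports. "The series", "measured", "known", "first", "only" and "open" are said of these compounds alone.

Compound 1 `O=c1[nH]c(-c2cccc3ccccc23)nc2ccc(N3CCCCC3)cc12`: > 50000 nM
Compound 2 `Cc1ccc2nc(-c3ccccc3C(F)(F)F)[nH]c(=O)c2c1`: > 50000 nM
Compound 3 `Cc1cccc(-c2nc3cc(C)ccc3c(=O)[nH]2)c1`: > 50000 nM

In a functional assay on T47D cells (Homo sapiens) for cytotoxicity, read by MTT assay, with a stated time of 2 days (on this read-out lower numbers stand for stronger inhibition and higher numbers for weaker inhibition), compound 2 reaches only a limit of the assay, not a number. The same holds for every compound measured here, since all three values sit at the limit of > 50000 nM in this assay, at which 3 of the 3 values shown sit. Nothing among these three shows any difference that could be followed, so no measured step exists to guide a prediction.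

Compound 4 `Cc1ccc2nc(-c3ccccc3N(C)C)[nH]c(=O)c2c1` is the untested compound. It differs from compound 2 by dimethylamino in place of trifluoromethyl on an aromatic carbon. Going by the values given here, with no measured step to rest on, the expected change from compound 2 to compound 4 in this assay is none beyond the usual scatter, and compound 4 is most likely to end at the same limit. Compound 4 is estimated at 50000 nM, in a range from 20000 nM to 100000 nM, a step of a number no higher from compound 2 to compound 4 (the limit leaves the size open).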

Compound 4, half-maximal inhibitory concentration: 26700 nM
Compound 4: the middle estimate sits 1.9-fold (0.27 log units) above what was measured; the range from low to high includes it.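

Dimethylamino in place of trifluoromethyl on an aromatic carbon, ortho to a large group, gives an at least 1.8-fold lower number from compound 2 to compound 4 (0.27 log units; that floor lies within the scatter) in this assay. Compound 4 is the only compound shown that returns a number, so this position is the first place where a change can be read at all. Only a floor for the step is known, because compound 2 gives just a limit of the assay: the limit of > 50000 nM in this assay, at which 3 of the 4 values shown sit.

From the compounds shown here alone, whether a primary amine or a carboxylic acid at this position would give a lower number stays open. So does the true size of this step.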